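The source may hold more compounds than are shown below. What is called first, only, known or untested is meant among the compounds shown, and "the series" means these compounds.

Measured so far in an assay on HEK293 cells for inhibition of solute carrier family 22 member 12 (Homo sapiens), read by scintillation counting, with a stated time of 12 min; a higher number here means a weaker inhibitor, a lower number a stronger inhibitor:
compound 1 `N#CCCc1ccc2nccc(SC3(C(=O)O)CCC3)c2c1`: 2760 nM
compound 2 `COCc1ccc2nccc(SC3(C(=O)O)CCC3)c2c1`: 198 nM

Compound 2 gives the lowest of the two numbers in this assay; the nearest is compound 1, and the step of a 14-fold lower number from compound 1 to compound 2 (1.14 log units; beyond the scatter) lies beyond the scatter. Compound 3 `CNC(=O)COc1ccc2nccc(SC3(C(=O)O)CCC3)c2c1` is not yet measured. It differs from compound 2 in one place: (methylcarbamoyl)methoxy in place of methoxymethyl on an aromatic carbon. Among the compounds with values here, the only measured step, a 14-fold lower number from compound 1 to compound 2 (1.14 log units; beyond the scatter), shows that what sits on this aromatic carbon moves the number a great deal; that step swapped a group on a saturated chain carbon, whereas here the whole group on the aromatic carbon is exchanged for a longer one carrying an amide. Within the data shown here, it gives no direct precedent for the direction. A change beyond the scatter in either direction is plausible; the expectation is a modest weakening. Compound 3 is therefore estimated at 400 nM (range 100 nM to 1600 nM), an expected step of a 2.0-fold higher number from compound 2 to compound 3 (0.31 log units; beyond the scatter).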

Compound 3, half-maximal inhibitory concentration: > 10000 nM
Compound 3 ended at the assay's limit (the forecaster's own chance of this, stated with the estimate: 5%); middle value at least 25-fold (1.39 log units) from the limit.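

Compound 3 sits at a limit of the assay, not at a number: the limit of > 10000 nM in this assay, at which 1 of the 3 values shown sits. In this assay, the change therefore reads only as a bound, with an at least 50-fold higher number from compound 2 to compound 3 (1.70 log units; beyond the scatter) and an at least 3.6-fold higher number from compound 1 to compound 3 (0.55 log units; beyond the scatter). Going by these compounds, on this aromatic carbon, (methylcarbamoyl)methoxy thus gives a weaker inhibitor than either methoxymethyl or 2-cyanoethyl, a ranking that the first two compounds could not give, and how much weaker remains unknown.

The entering group differs from methoxymethyl in length and in carrying an amide, so the compounds shown do not say which of these features goes with the loss. A plain methoxy, a primary amide or a carboxylic acid on the same chain would begin to separate them.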